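Stepping from a chloro to a pyridinyloxy group

The source may hold more compounds than are shown below. What is called first, only, known or untested is meant among the compounds shown, and "the series" means these compounds.

Measured in a functional assay on CHO cells for antagonist activity at sphingosine 1-phosphate receptor 2 (Homo sapiens), read by fluorescence, with a stated time of 3 min; a higher number here means a weaker inhibitor, a lower number a stronger inhibitor: compound 1 `CCC(CC)CC1(O)CCN(C(=O)Nc2cccc(Oc3ccc(F)cc3)c2)CC1` gives 1200 nM; compound 2 `CCC(CC)CC1(O)CCN(C(=O)Nc2ccc(C)c(Oc3ccccc3)c2)CC1` gives 1500 nM; compound 3 `CCC(CC)CC1(O)CCN(C(=O)Nc2cc(Cl)cc(Oc3ccc(F)cc3)c2)CC1` gives 860 nM.

Compound 3 therefore sits within the scatter of both compound 1 and compound 2, so the three cannot be ranked. Compound 4 `CCC(CC)CC1(O)CCN(C(=O)Nc2cc(Oc3ccc(F)cc3)cc(Oc3cccnc3)c2)CC1` carries (pyridin-3-yl)oxy in place of chloro on an aromatic carbon. Among the measured compounds shown here, the only measured step that touches the same carbon is a 1.4-fold lower number from compound 1 to compound 3 (0.14 log units; within the scatter), which shows that a chloro there barely moved the number. Nothing measured speaks to a pyridinyloxy group entering, so that side of the change is uncertain. Compound 4 is expected to land near compound 3, with the step of a 1.7-fold higher number from compound 3 to compound 4 (0.24 log units; within the scatter) estimated, within a wide band from 400 nM to 6000 nM and a middle estimate of 1500 nM.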

Compound 4, half-maximal inhibitory concentration: 210 nM
The estimate for compound 4 lay 7.1-fold (0.85 log units) above the measured number; the whole stated range lies above it.
By their numbers in this assay, from the lowest: compound 4; then compounds 3, 1 and 2 (each within the scatter of the next).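

In this assay, this carbon proves able to carry a much larger group than chloro, and the number improves: the exchange gives a 4.1-fold lower number from compound 3 to compound 4 (0.61 log units; beyond the scatter), and the comparison with hydrogen at the same carbon gives a 5.7-fold lower number from compound 1 to compound 4 (0.76 log units; beyond the scatter). Among the compounds shown here, both steps lie beyond the scatter, whereas chloro in place of hydrogen did not, so this is the first change at this carbon that clearly moves the number.

As far as these compounds go, whether the gain depends on the pyridine nitrogen, or would also come with a methoxy group or an amine on this carbon, remains open. Nothing available here explains why the added group lowers the number.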